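Swapping the carbamate cap on compound 3's piperazine

A few compounds are considered here, and "the series" means these few. Any claim that something is new, unique, unknown or untested is made for them only; others in the source may bear on it.

Compound 3 `CCCCCCCCCCn1cc(/C=C/C(=O)c2ccc(NC(=O)CN3CCN(C(=O)OC(C)(C)C)CC3)cc2)nn1` is the least potent of the three measured compounds in a functional assay on SK-N-SH cells (Homo sapiens) for inhibition, read by MTT assay (a higher number here means a weaker inhibitor, a lower number a stronger inhibitor), where compound 3 gives 77800 nM. Going by the values given here, its nearest neighbour is compound 2 `CCCCCCCCn1cc(/C=C/C(=O)c2ccc(NC(=O)CN3CCN(C(=O)OC(C)(C)C)CC3)cc2)nn1`, which in this assay gives 38000 nM; the only single-point step among the measured compounds is a 2.0-fold higher number from compound 2 to compound 3 (0.31 log units; beyond the scatter). Further off stands compound 1 `O=C(CN1CCN(c2ccccc2F)CC1)Nc1ccc(C(=O)/C=C/c2cn(Cc3ccc(Br)cc3)nn2)cc1`, which in this assay gives 12800 nM; compound 1 differs from compound 3 in two places at once, so its value alone cannot be assigned to either change.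

Compound 4 `CCCCCCCCCCn1cc(/C=C/C(=O)c2ccc(NC(=O)CN3CCN(c4ccccc4F)CC3)cc2)nn1` arises from compound 3 by 2-fluorophenyl in place of tert-butoxycarbonyl on an amine nitrogen in a ring. Among the compounds with values here, no measured step isolates this change. Within the data shown here, the only hint comes from compound 1, which carries the same 2-fluorophenyl piperazine and gives 12800 nM, but also a different group on the triazole. A modest improvement is therefore expected, with wide uncertainty, as a 1.9-fold lower number from compound 3 to compound 4 (0.29 log units; within the scatter). Compound 4 is expected to give about 40000 nM in this assay, within a range from 12000 nM to 130000 nM.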

Compound 4, half-maximal inhibitory concentration: 34400 nM
Compound 4: the middle estimate sits 1.2-fold (0.07 log units) above what was measured; low and high end bracket the measured number.
By their numbers in this assay, from the lowest: compound 1; then compounds 4 and 2 (each within the scatter of the next); then compound 3.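

With the rest of compound 3 unchanged, 2-fluorophenyl in place of tert-butoxycarbonyl on the amine nitrogen in a ring gives a 2.3-fold lower number from compound 3 to compound 4 (0.35 log units; beyond the scatter) in this assay, so this position responds to the swap, though only modestly. Compound 1 and compound 4 share the 2-fluorophenyl group. The group on the triazole can now be read alone: nonyl in place of 4-bromophenyl on a saturated chain carbon bound to an aromatic nitrogen gives a 2.7-fold higher number from compound 1 to compound 4 (0.43 log units; beyond the scatter). Nothing available explains either step.

Still open, from the compounds shown here alone, is how other groups on that amine nitrogen, such as an unsubstituted phenyl, an acetyl or a benzyl, would read. Also open, going by these compounds, is whether an amine or a carboxylic acid at the end of the chain on the aromatic nitrogen would move the number.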